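Sigma-1 binding: replacing a methoxy group with a hydroxy group

The compounds below may be only part of what the source reports. "The series", "measured", "known", "first", "only" and "open" are said of these compounds alone.

Measured compounds:
- Compound 1, `c1ccc2c(c1)CCCC2CCCN1CCN(C2CCCCC2)CC1`: 0.61 nM
- Compound 2, `COc1ccc2c(c1)CCCC2CCCN1CCN(C2CCCCC2)CC1`: 0.36 nM
- Compound 3, `COc1cccc2c1CCCC2CCCCCCN1CCN(C2CCCCC2)CC1`: 3.07 nM

All three were tested in an assay on membranes from brain (Cavia porcellus) for binding affinity to Sigma non-opioid intracellular receptor 1 (Homo sapiens); a higher number here means a weaker inhibitor, a lower number a stronger inhibitor. Compound 2 has the lowest number of the three; compound 1 sits closest to it, and that gap, a 1.7-fold lower number from compound 1 to compound 2 (0.23 log units; within the scatter), is within the usual scatter, so the two cannot be ranked against each other. Compound 3, with its longer chain and a methoxy group on a different aromatic carbon, gives a higher number, and that gap is beyond the scatter.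

Compound 4, `Oc1ccc2c(c1)CCCC2CCCN1CCN(C2CCCCC2)CC1`, differs from compound 2 in one place: hydrogen in place of methyl on an oxygen on an aromatic ring. Going by the values given here, the one measured step, from compound 1 to compound 2, concerns the arrival of the whole methoxy group and was small; no measured pair shows what removing only the methyl from that oxygen does. Among the compounds with values here, with no direct precedent, the safest expectation is a change no larger than the scatter, with some chance of a modest rise in the number. The step from compound 2 to compound 4 is therefore expected to be a 1.7-fold higher number from compound 2 to compound 4 (0.22 log units; within the scatter). In this assay compound 4 is estimated at 0.6 nM, with a likely range from 0.2 nM to 2 nM.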

Compound 4, inhibition constant: 0.69 nM
The estimate for compound 4 lay 1.2-fold (0.06 log units) below the measured number, and the stated range covers the measured number.
By their numbers in this assay, from the lowest: compounds 2, 1 and 4 (each within the scatter of the next); then compound 3.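

In this assay, removing only the methyl from the oxygen on the aromatic ring, which turns methoxy into hydroxy, gives a 1.9-fold higher number from compound 2 to compound 4 (0.28 log units; within the scatter), a step within the scatter that isolates a change no earlier pair had shown on its own. Putting hydroxy in place of hydrogen on that same aromatic carbon gives a 1.1-fold higher number from compound 1 to compound 4 (0.05 log units; within the scatter), also within the scatter, so together with the earlier step from hydrogen to methoxy, this measurement cannot separate hydrogen, methoxy and hydroxy at this position. The data offer no measured explanation for why these three groups cannot be told apart here.

Whether this position stays as undemanding with a quite different group, such as an amine, a carboxylic acid or a fluorine atom, remains open, since all three groups compared here are small and none of those appears among the compounds shown. Compound 3 differs from the others in both its longer chain and the place of its methoxy group, so the contribution of each of those two differences also remains unresolved.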